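Swapping the aryl ether end on a thiazole amide

A few compounds are considered here, and "the series" means these few. Any claim that something is new, unique, unknown or untested is made for them only; others in the source may bear on it.

Compound 1 `Cc1ccc(-c2csc(NC(=O)COc3ccccc3C)n2)cc1` gives 52100 nM in a functional assay on MDA-MB-468 cells (Homo sapiens) for cytotoxicity, read by MTT assay, with a stated time of 48 h; on this read-out higher numbers stand for weaker inhibition and lower numbers for stronger inhibition. Compound 2 `Cc1ccc(-c2csc(NC(=O)COc3ccc(F)cc3F)n2)cc1` differs by 2,4-difluorophenyl in place of 2-methylphenyl on an oxygen on a saturated carbon and gives 10500 nM, which is a 5.0-fold lower number from compound 1 to compound 2 (0.70 log units; beyond the scatter). Compound 3 `Cc1ccccc1OCC(=O)Nc1nc(-c2ccc(Cl)cc2)cs1` differs from compound 1 by chloro in place of methyl on an aromatic carbon; in this assay compound 3 gives 40100 nM, a step of a 1.3-fold lower number from compound 1 to compound 3 (0.11 log units; within the scatter). Compound 4 `O=C(COc1ccc(F)cc1F)Nc1nc(-c2ccc(Cl)cc2)cs1` has not been measured; it differs from compound 3 by 2,4-difluorophenyl in place of 2-methylphenyl on an oxygen on a saturated carbon, the same change seen from compound 1 to compound 2, which occurs in two pairs of compounds here. Because that change gave a 5.0-fold lower number from compound 1 to compound 2 (0.70 log units; beyond the scatter), and because the core change gave only a 1.3-fold lower number from compound 1 to compound 3 (0.11 log units; within the scatter), a step of similar size is expected from compound 3 to compound 4, a 4.5-fold lower number from compound 3 to compound 4 (0.65 log units; beyond the scatter). Compound 4 is therefore estimated at 9000 nM, with a likely range from 3000 nM to 30000 nM.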

Compound 4, half-maximal inhibitory concentration: 32900 nM
Compound 4: middle estimate off by 3.7-fold (0.56 log units), on the low side; the measured number lies above the stated range.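

The swap to 2,4-difluorophenyl gives a 1.2-fold lower number from compound 3 to compound 4 (0.09 log units; within the scatter) in this assay, so it does not carry over at full size from the methyl-bearing core: the same change on two cores in this assay, a 5.0-fold lower number (0.70 log units; beyond the scatter) from compound 1 to compound 2 and a 1.2-fold lower number (0.09 log units; within the scatter) from compound 3 to compound 4, 4.1-fold (0.61 log units) apart, beyond the scatter of two such steps. Read the other way, chloro in place of methyl gives a 3.1-fold higher number from compound 2 to compound 4 (0.50 log units; beyond the scatter), so the effect of that change also depends on the group at the other end of the molecule: the same change on two cores in this assay, a 1.3-fold lower number (0.11 log units; within the scatter) from compound 1 to compound 3 and a 3.1-fold higher number (0.50 log units; beyond the scatter) from compound 2 to compound 4, 4.1-fold (0.61 log units) apart, beyond the scatter of two such steps. These four compounds show that the two changes do not act independently here, but they do not show why, or whether this holds for other groups.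

Going by these compounds, it remains open whether the same mismatch would appear with a plain phenyl or a pyridine ring on the oxygen. The same question applies to bromo in place of chloro on the aromatic carbon.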